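The source may report more compounds than this note shows. Statements on the series, on what has been measured and on what is new or still open speak of the compounds shown alone.

In an ADME assay on Huh7.5.1 cells (Homo sapiens) for cytotoxicity, read by WST assay, with a stated time of 48 h (on this read-out lower numbers stand for higher toxicity in this test and higher numbers for lower toxicity in this test), compound 2 (`Cc1c(-c2ccc(Oc3ccc(N(C)C)cc3)c(F)c2)[nH]c2cccc(F)c2c1=O`) gives > 10000 nM as a limit, not a number. Compound 1 (`Cc1c(-c2ccc(Oc3ccc(N4CCCCC4)cc3)c(F)c2)[nH]c2cccc(F)c2c1=O`) gives > 10000 nM as a limit too. Compound 2 therefore offers no exact starting value, and the record holds only the limit of > 10000 nM in this assay, at which 2 of the 2 values shown sit, and nothing firmer. Compound 3 (`CCNc1ccc(Oc2ccc(-c3[nH]c4cccc(F)c4c(=O)c3C)cc2F)cc1`) alters the same group of compound 2, with ethylamino in place of dimethylamino on an aromatic carbon. Going by the values given here, the one measured step at this place is a step that the two limits leave unreadable from compound 1 to compound 2 and it gives no size to build on, but both of its ends stay at the limit. No shift beyond the usual scatter, and no direction, is therefore expected in this assay, and the estimated step is a step that the limit leaves unreadable from compound 2 to compound 3 as a rough guide. A reading at the same limit is the likeliest result. For compound 3 the estimate is 15000 nM with an expected range from 6000 nM to 40000 nM in this test.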

Compound 3, half-maximal cytotoxic concentration: > 10000 nM
Compound 3 ended at the assay's limit; the forecaster's own chance of this, stated with the estimate: 75%; the middle value lies beyond the limit too.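

No new step can be read, because compound 1, compound 2 and compound 3 all end at a limit rather than a number: the limit of > 10000 nM in this assay, at which 3 of the 3 values shown sit. On these data alone, whether these three compounds differ at all in this assay, and at what concentration any of them harms the cells, stays open.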